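Trimming the Chain on the Charged Ring Nitrogen

A few compounds are considered here, and "the series" means these few. Any claim that something is new, unique, unknown or untested is made for them only; others in the source may bear on it.

Measured compounds:
- compound 1 `CCN1CCc2c(sc(NC(=O)Nc3ccc(Cl)cc3)c2C(=O)c2nnco2)C1`: > 25000 nM
- compound 2 `CC(C)(C)OC(=O)CCCC[N+]1(C)CCc2c(sc(NC(=O)Nc3ccc(Cl)cc3)c2C(N)=O)C1`: 140 nM

In a functional assay (strain AB) with Danio rerio as the target, read by microscopy, with a stated time of 1 h (on this read-out higher numbers stand for an effect only at larger amounts of compound and lower numbers for an effect already at smaller amounts), compound 1 gives only a limit, > 25000 nM, not a number; (the limit of > 25000 nM in this assay, at which 1 of the 2 values shown sits). In this assay, among the compounds with values here, compound 2 gives 140 nM, the only real number so far, so compound 2 stands alone as the single measured point with a value.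

Compound 3 `CC(C)[N+]1(C)CCc2c(sc(NC(=O)Nc3ccc(Cl)cc3)c2C(N)=O)C1` is not yet measured. It differs from compound 2 in one place: isopropyl in place of 4-(tert-butoxycarbonyl)butyl on an amine nitrogen in a ring. Within the data shown here, no measured pair differing in one place is available, so the size of this step is unknown. The change removes a long chain with an ester and puts a short branched group in its place. The step from compound 2 to compound 3 is expected to be moderate and toward weaker effect, a 2.9-fold higher number from compound 2 to compound 3 (0.46 log units; beyond the scatter), though it could fall within the scatter. Compound 3 is estimated to give 400 nM, with a range from 100 nM to 2000 nM.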

Compound 3, half-maximal effective concentration: 960 nM
Compound 3: middle estimate off by 2.4-fold (0.38 log units), on the low side; the range from low to high includes it.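

In this assay, within the data shown here, this is the first pair of compounds that differ in one place, and it shows that the group on the charged ring nitrogen matters: putting isopropyl in place of 4-(tert-butoxycarbonyl)butyl gives a 6.9-fold higher number from compound 2 to compound 3 (0.84 log units; beyond the scatter) in this series. The long chain with its ester is still not required for a measurable effect, since compound 3 gives 960 nM as a real number and not a limit. No measurement shown explains the size of this step.

The two compounds leave open whether the difference follows the length of the chain or the ester at its end. A plain pentyl chain, or a carboxylic acid in place of the tert-butyl ester, would help to separate those two possibilities.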